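The compounds below may be only part of what the source reports. "The series", "measured", "known", "first", "only" and "open" are said of these compounds alone.

Measured so far in a physicochemical assay for solubility, using the shake flask method, in simulated intestinal fluid, measured as kinetic solubility, with a stated time of 20 h, at pH 6.5 (on this read-out higher numbers stand for higher solubility and lower numbers for lower solubility), are three compounds.
- compound 1 `Fc1ccc(-c2nc3cnc(Nc4ccc(C(F)(F)F)cn4)cc3[nH]2)cc1F` gives >= 50000 nM as a limit of the assay, not a number.
- compound 2 `FC(F)(F)c1ccc(Nc2cc3[nH]c(C4CCCC4)nc3cn2)nc1` gives 85000 nM as a number.
- compound 3 `FC(F)(F)c1ccc(Nc2cc3[nH]c(C4CCOC4)nc3cn2)nc1` gives 180000 nM as a number.

Compound 3 holds the higher of the two actual numbers, and compound 2 is its nearest neighbour. The value of compound 1 is a limit, so it cannot be placed against them. Neither a step that the limit leaves unreadable from compound 1 to compound 2 nor a step that the limit leaves unreadable from compound 1 to compound 3 gives a usable size.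

Compound 4 `FC(F)(F)c1ccc(Nc2cc3[nH]c(CC4CC4)nc3cn2)nc1` is not yet measured. The change is cyclopropylmethyl in place of oxolan-3-yl on an aromatic carbon and in words it is cyclopropylmethyl in place of oxolan-3-yl on an aromatic carbon.

Among the compounds with values here, the only readable step that bears on this is a 2.1-fold higher number from compound 2 to compound 3 (0.33 log units; beyond the scatter) and it is modest. That step brought in oxolan-3-yl for cyclopentyl. Compound 4 again carries a group of carbon only, so it is expected to fall back toward compound 2 at 85000 nM in this read-out. This rests on a single step. In this assay an estimated 2.0-fold lower number from compound 3 to compound 4 (0.30 log units; within the scatter) is expected. For compound 4 the estimated value is 90000 nM with an expected range from 35000 nM to 200000 nM in this read-out.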

Compound 4, solubility: 156000 nM
The estimate for compound 4 lay 1.7-fold (0.24 log units) below the measured number, within the range that was stated.
By their numbers in this assay, from the lowest: compounds 2, 4 and 3 (each within the scatter of the next, the first and the last beyond it).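

In this assay the change from oxolan-3-yl to cyclopropylmethyl gives a 1.2-fold lower number from compound 3 to compound 4 (0.06 log units; within the scatter), so removing the ring oxygen at this position does not by itself separate the two compounds. The other readable comparison gives a 1.8-fold higher number from compound 2 to compound 4 (0.26 log units; within the scatter), which leaves compound 4 within the scatter of both compound 2 and compound 3, although those two lie beyond the scatter of each other. The link between a ring oxygen and a higher number, which rested on a single step, finds no support in compound 4, a carbon-only case that goes against it.

The value of compound 1 is a limit, so its steps to the other compounds cannot be read: the limit of >= 50000 nM in this assay, at which 1 of the 4 values shown sits. Also open, as far as these compounds go, is where an amine, a carboxylic acid or a longer chain at this position would fall in this assay.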